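The compounds below may be only part of what the source reports. "The series", "measured", "known", "first", "only" and "open" are said of these compounds alone.

Measured in a functional assay on A549 cells (Homo sapiens) for inhibition, read by sulforhodamine B assay, with a stated time of 48 h; on this read-out lower numbers stand for stronger inhibition of growth and higher numbers for weaker inhibition of growth:
compound 1 `COC1=C(OC)[C@H](O)[C@H](C/C=C(\C)CC/C=C(\C)C/C=C/C(C)(C)O)[C@@H](C)C1=O` — 23800 nM
compound 2 `COC1=C(OC)[C@H](OC(C)=O)[C@H](C/C=C(\C)CC/C=C(\C)C[C@@H]2C[C@@H](C)C(=O)O2)[C@@H](C)C1=O` — 11300 nM
compound 3 `COC1=C(OC)[C@H](OC(C)=O)[C@H](C/C=C(\C)CC/C=C(\C)C[C@H](O)C[C@@H](C)C(O)O)[C@@H](C)C1=O` — 15400 nM

Compound 1 gives the highest of the three numbers: against compound 3 the gap is within the scatter, against compound 2 it lies beyond it. Compound 4 `COC1=C(OC)[C@H](O)[C@H](C/C=C(\C)CC/C=C(\C)CCCC(C)CO)[C@@H](C)C1=O` differs from compound 1 only at the chain end: 3-(hydroxymethyl)butyl in place of 3-hydroxy-3-methylbut-1-en-1-yl on a saturated chain carbon bound to a double-bonded chain carbon. Among the measured compounds shown here, the single step available, a 1.4-fold higher number from compound 2 to compound 3 (0.13 log units; within the scatter), also alters the chain end at the same place, and stayed within the scatter, but it is not a change of the same kind, so it bears on the present step only loosely. For the measured compounds named here, no measured pair reports a change like this one. For compound 4 the expected step is therefore none beyond the scatter, a 1.0-fold higher number from compound 1 to compound 4 (0.00 log units; within the scatter). Compound 4 is estimated in this assay at 24000 nM, between 10000 nM and 58000 nM.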

Compound 4, concentration for 50% growth inhibition: 7100 nM
The estimate for compound 4 lay 3.4-fold (0.53 log units) above the measured number; the measured number lies below the stated range.
By their numbers in this assay, from the lowest: compounds 4, 2, 3 and 1 (each within the scatter of the next, the first and the last beyond it).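

In this assay, among the compounds shown here, this is the first change on a saturated chain carbon bound to a double-bonded chain carbon to go beyond the scatter: a 3.4-fold lower number from compound 1 to compound 4 (0.53 log units; beyond the scatter). The step replaces 3-hydroxy-3-methylbut-1-en-1-yl with 3-(hydroxymethyl)butyl, so the number responds even though the heavy-atom, donor and acceptor counts stay the same. No measurement at hand gives a cause for this step.

As far as these compounds go, whether the loss of the double bond or the new place of the hydroxyl carries the step remains open, as the two change together. From the compounds shown here alone, how a carboxylic acid or an amine at this chain end would compare is also open.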